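Cytotoxicity series on a shared furanone-free core: propyl to isobutyl amide

A few compounds are considered here, and "the series" means these few. Any claim that something is new, unique, unknown or untested is made for them only; others in the source may bear on it.

Measured so far in a functional assay on SW480 cells (Homo sapiens) for cytotoxicity, read by MTT assay, with a stated time of 24 h; a higher number here means a weaker inhibitor, a lower number a stronger inhibitor:
Compound 1 `C=CC1=C(C(=O)NCCC)C(c2ccc(Cl)c(Cl)c2)OC1` gives > 100000 nM, a limit of the assay.
Compound 2 `C=CC1=C(C(=O)NCc2ccc(C)cc2)C(c2ccc(F)cc2)OC1` gives > 100000 nM, a limit of the assay.
Compound 3 `C=CC1=C(C(=O)NC2CCCCC2)C(c2ccc(F)cc2)OC1` gives > 100000 nM, a limit of the assay.

Compound 1 stands only at a limit in this assay, as do the other two. Among the compounds with values here, the one measured step, a step that the two limits leave unreadable from compound 2 to compound 3, is unreadable, since both ends are limits. Compound 4 `C=CC1=C(C(=O)NCC(C)C)C(c2ccc(Cl)c(Cl)c2)OC1` differs from compound 1 by methyl in place of hydrogen on a saturated chain carbon bound to two saturated chain carbons. Within the data shown here, no measured step bears on this change. Because (the limit of > 100000 nM in this assay, at which 3 of the 3 values shown sit), nothing here points to a step beyond the scatter in this assay, and a further limit is the most likely read-out. Compound 4 is therefore expected to give about 200000 nM, within 50000 nM to 1000000 nM, an expected step that the limit leaves unreadable from compound 1 to compound 4.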

Compound 4, half-maximal inhibitory concentration: > 100000 nM
Compound 4: only a limit was reported; the forecaster's own chance of this, stated with the estimate: 85%; the middle value lies beyond the limit too.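

Within the data shown here, compound 1 and compound 4 both stand only at a limit in this assay, and no step between them can be read. The compounds shown leave open whether any change on the shared core gives a measurable value in this assay.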